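The source may report more compounds than this note shows. Statements on the series, on what has been measured and on what is new or still open speak of the compounds shown alone.

Measured compounds in an assay on isolated protein for inhibition of Nicotinamide phosphoribosyltransferase (Homo sapiens), read by mass spectrometry, with stated times of 15 min and 30 min; a higher number here means a weaker inhibitor, a lower number a stronger inhibitor:
- compound 1 `O=C(NCc1ccc(S(=O)(=O)c2cccc(C(F)(F)F)c2)cc1)N1Cc2ccncc2C1` gives 8 nM
- compound 2 `O=C(NCc1ccc(S(=O)(=O)C2CCCOC2)cc1)N1Cc2ccncc2C1` gives 44 nM
- compound 3 `CN1CCC(S(=O)(=O)c2ccc(CNC(=O)N3Cc4ccncc4C3)cc2)CC1` gives 48 nM

Compound 3 carries the highest of the three numbers, but its gap to compound 2 is small: a 1.1-fold higher number from compound 2 to compound 3 (0.04 log units; within the scatter). Both saturated six-membered groups on the sulfonyl sulfur sit well apart from the aryl group of compound 1: a 5.5-fold higher number from compound 1 to compound 2 (0.74 log units; beyond the scatter) and a 6.0-fold higher number from compound 1 to compound 3 (0.78 log units; beyond the scatter).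

Compound 4 `O=C(NCc1ccc(S(=O)(=O)N2CCC[C@@H](O)C2)cc1)N1Cc2ccncc2C1` is not yet measured. Its change from compound 3 is 3-hydroxypiperidin-1-yl in place of 1-methylpiperidin-4-yl on a sulfonyl sulfur. The step that bears most directly is the swap between compound 2 and compound 3, where one saturated six-membered group with one heteroatom replaced another without movement beyond the scatter; compound 4 keeps a saturated six-membered ring with one heteroatom on the same sulfur, now with a hydrogen-bond donor and a defined stereocentre. Going by the values given here, no measured step shows the effect of the ring being joined through nitrogen or of adding a hydroxyl. The expectation is therefore a step of about a 1.0-fold higher number from compound 3 to compound 4 (0.02 log units; within the scatter), within the scatter, with wider uncertainty than the measured pairs. Compound 4 is estimated at 50 nM in this assay, within a range of 18 nM to 150 nM.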

Compound 4, half-maximal inhibitory concentration: 28 nM
Beside the measured number, compound 4's estimate is 1.8-fold (0.25 log units) above it, and the stated range covers the measured number.
By their numbers in this assay, from the lowest: compound 1; then compounds 4, 2 and 3 (each within the scatter of the next).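

In this assay the sulfonyl sulfur accepts a saturated ring joined through its nitrogen and bearing a hydroxyl, with no shift beyond the scatter against the 1-methylpiperidin-4-yl group (a 1.7-fold lower number from compound 3 to compound 4 (0.23 log units; within the scatter)) or the oxan-3-yl group (a 1.6-fold lower number from compound 2 to compound 4 (0.20 log units; within the scatter)). The 3-hydroxypiperidin-1-yl group still stands apart from the 3-(trifluoromethyl)phenyl group (a 3.5-fold higher number from compound 1 to compound 4 (0.54 log units; beyond the scatter)), so all three saturated groups shown now lie beyond the scatter from that aryl group. No available evidence explains these steps.

Ring attachment through nitrogen and the hydroxyl change together in compound 4, so their separate contributions cannot be read. Still open, from the compounds shown here alone, are plain piperidin-1-yl, the opposite configuration of the hydroxyl-bearing carbon, and a carboxylic acid on the ring.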